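The compounds below may be only part of what the source reports. "The series", "measured", "known", "first", "only" and "open" are said of these compounds alone.

Measured so far, in a functional assay on the whole organism with Mus musculus as the target, in the maximal electroshock model, at a dose of 50 mg/kg by the oral route; on this read-out higher numbers stand for more inhibition at the one dose given (going by the name of the read-out) and lower numbers for less inhibition:

compound 1 `COc1cccc(/C=C/c2ccccc2)c1OCCCCN(C)C` gives 57.1%
compound 2 `OC1CCN(CCCCOc2ccccc2/C=C/c2ccccc2)CC1` gives 0%
compound 3 `CN1CCN(CCCCOc2ccccc2/C=C/c2cccc(Cl)c2)CC1` gives 0%

Compound 2 stands at the bottom of these three numbers together with compound 3, whose result matches it at the digits shown and lies within the usual scatter. The furthest value belongs to compound 1, whose result in this assay is higher by an amount that goes beyond the scatter.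

Compound 4 `O=C(O)C1CCCN(CCCCOc2ccccc2/C=C/c2ccccc2)C1` is not yet measured. It differs from compound 2 in one place: 3-carboxypiperidin-1-yl in place of 4-hydroxypiperidin-1-yl on a saturated chain carbon, four bonds along the chain from an oxygen on an aromatic ring. Among the compounds with values here, no measured pair in this set shows the effect of such a change, so nothing here tells how large a move to expect in either direction. Given that compound 2 gives 0% and that the change stays on the same chain, the step from compound 2 to compound 4 in this assay is expected to be modest, a number 10 percentage points higher from compound 2 to compound 4 (within the scatter), and not clearly beyond the scatter. Compound 4 is therefore estimated at 10%, with a range from 0% to 40%.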

Compound 4, a percentage reported as inhibition, in the whole organism at one dose (the size of the read-out at that dose, not a potency): 12.5%
Compound 4: middle estimate off by 2.5 percentage points, on the low side; the range from low to high includes it.
By their numbers in this assay, from the lowest: compounds 2 and 3 (each within the scatter of the next); then compound 4; then compound 1.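

In this assay, putting 3-carboxypiperidin-1-yl in place of 4-hydroxypiperidin-1-yl on the chain gives a number 12.5 percentage points higher from compound 2 to compound 4 (beyond the scatter). Within the data shown here, this is the first step in the set that changes only one place, and it shows that the group at the end of this four-bond stretch of chain can alter the result: a compound at 0%, compound 2, is not fixed there by its shared core alone. Nothing available explains why the number moves with this change.

The step swaps two things at once, the kind of substituent on the piperidine ring and where it sits, so the compounds shown cannot separate the two. A 4-carboxypiperidin-1-yl or 3-hydroxypiperidin-1-yl group would pull these apart, while a plain piperidin-1-yl group or the methyl ester of the carboxylic acid would show whether the acid group itself matters.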